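This account rests on a few compounds, and the source may have more. Where it says the series, first, only, none or still open, it means among the compounds named here.

Compound 3 `COc1ccc(-c2cn(C[C@H](O)[C@H]3OC(=O)C(OCc4ccccc4)=C3OCc3ccccc3)nn2)cc1` stands at the edge of what a functional assay on HCT-116 cells (Homo sapiens) for antiproliferative activity, read by MTT assay, with a stated time of 72 h (on this read-out lower numbers stand for stronger inhibition and higher numbers for weaker inhibition), can report: in this assay compound 3 gives > 100000 nM, which is a limit of the assay and not a number. Compound 1 `Cc1ccc(S(=O)(=O)NCc2cn(C[C@H](O)[C@H]3OC(=O)C(OCc4ccccc4)=C3OCc3ccccc3)nn2)cc1` gives 13100 nM in this assay, and compound 2 `O=C1O[C@H]([C@@H](O)Cn2cc(CNS(=O)(=O)c3ccc(F)cc3)nn2)C(OCc2ccccc2)=C1OCc1ccccc1` gives 22900 nM. Both steps toward compound 3 run to weaker inhibition, an at least 7.6-fold higher number from compound 1 to compound 3 (0.88 log units; beyond the scatter) and an at least 4.3-fold higher number from compound 2 to compound 3 (0.64 log units; beyond the scatter), each ending at the limit (the limit of > 100000 nM in this assay, at which 1 of the 3 values shown sits). Compound 4 `O=C1O[C@H]([C@@H](O)Cn2cc(CCO)nn2)C(OCc2ccccc2)=C1OCc1ccccc1` differs from compound 3 at one place: 2-hydroxyethyl in place of 4-methoxyphenyl on an aromatic carbon. Within the data shown here, no measured step shows what 2-hydroxyethyl does here; the measured steps only show that the 4-methoxyphenyl of compound 3 lies beyond the limit, whereas the (((4-methylphenyl)sulfonyl)amino)methyl and (((4-fluorophenyl)sulfonyl)amino)methyl groups give measurable numbers. Compound 4 is therefore expected to return to a measurable value, though not far from the limit, with an estimate of 60000 nM, between 15000 nM and 200000 nM. This estimate means an expected step of an at least 1.6-fold lower number from compound 3 to compound 4 (0.22 log units; that floor lies within the scatter) toward stronger inhibition.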

Compound 4, half-maximal inhibitory concentration: 72700 nM
The estimate for compound 4 lay 1.2-fold (0.08 log units) below the measured number; measured number inside the range.
By their numbers in this assay, from the lowest: compounds 1 and 2 (each within the scatter of the next); then compound 4. At a limit, above all of these: compound 3.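

In this assay, replacing the 4-methoxyphenyl with 2-hydroxyethyl on this aromatic carbon of the five-membered ring returns a measurable number, so a six-membered aromatic ring is not needed here for a reading, though the step, an at least 1.3-fold lower number from compound 3 to compound 4 (0.13 log units; that floor lies within the scatter), is only a floor. Compound 3 itself remains a limit of the assay and not a number: the limit of > 100000 nM in this assay, at which 1 of the 4 values shown sits. The sulfonyl-bearing chains still give stronger inhibition than the hydroxyl-ended chain, with a 3.2-fold higher number from compound 2 to compound 4 (0.50 log units; beyond the scatter) and a 5.5-fold higher number from compound 1 to compound 4 (0.74 log units; beyond the scatter), so swapping the ((4-fluorophenyl)sulfonyl)amino or ((4-methylphenyl)sulfonyl)amino group for hydroxymethyl costs a modest amount.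

On these data alone, what remains open is whether the change from compound 3 owes more to losing the ring or to gaining the hydroxyl. It is also unknown how a longer chain ending in hydroxyl, or a chain ending in an amine or a carboxylic acid, would read at this position.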